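The source may report more compounds than this note shows. Statements on the series, on what has been measured and on what is new or still open speak of the compounds shown alone.

Measured so far in an ADME assay on microsomes from liver (Rattus norvegicus) for metabolic stability, with a stated time of 10 min; a lower number here means that less of the compound is left, a higher number that more of the compound is left:
- Compound 1 `FC(F)(F)c1ccccc1-c1ccc2[nH]c(C3=NCC4(CCCCC4)O3)nc2c1`: 32%
- Compound 2 `FC(F)(F)c1ccccc1-c1ccc2[nH]c(C3=NOC4(CCCCC4)C3)nc2c1`: 75%

Of these two, compound 2 stands highest at 75%, and the gap down to compound 1 at 32% lies beyond the scatter. Compound 3 `Fc1ccccc1-c1ccc2[nH]c(C3=NOC4(CCCCC4)C3)nc2c1` changes compound 2 in one place: fluoro in place of trifluoromethyl on an aromatic carbon. Within the data shown here, no pair of measured compounds shows this swap, so any forecast in this assay is loose. A modest fall, barely beyond the scatter, is expected, with an estimated a number 12 percentage points lower from compound 2 to compound 3 (beyond the scatter). For compound 3 the estimated value is 63%, with an expected range from 40% to 85%.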

Compound 3, percent of the compound remaining: 55%
Compound 3: middle estimate off by 8 percentage points, on the high side, and the stated range covers the measured number.
By their numbers in this assay, from the lowest: compound 1; then compound 3; then compound 2.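

In this assay, fluoro in place of trifluoromethyl on this aromatic carbon, ortho to a large group, gives a number 20 percentage points lower from compound 2 to compound 3 (beyond the scatter). Among these compounds, this is the first one-place comparison, and it shows that the group at this position affects how much compound is left, with trifluoromethyl the better of the two. No available measurement gives a reason for this step. As far as these compounds go, whether a methoxy group or an amine here would leave more compound than trifluoromethyl stays open. So does whether the same swap would act alike on the core of compound 1.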